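Moving the fluorine on the aryl piperazine group

The source may hold more compounds than are shown below. What is called first, only, known or untested is meant among the compounds shown, and "the series" means these compounds.

Of the compounds shown here, three sharing one core have been measured. Compound 1 `Nc1scc(CN2CCN(c3cc(Cl)cc(Cl)c3)CC2)c1C(=O)c1ccc(Cl)cc1` gives -74% in a functional assay on CHO cells with adenosine receptor A1 (Homo sapiens) as the target, read by cAMP accumulation and immunoassay, with a stated time of 6 min, tested at 10 uM; on this read-out higher numbers stand for a weaker effect at the one concentration tested and lower numbers for a stronger effect. Compound 2 `Nc1scc(CN2CCN(c3ccncc3)CC2)c1C(=O)c1ccc(Cl)cc1` gives -15% in this assay, and compound 3 `Nc1scc(CN2CCN(c3cccc(F)c3)CC2)c1C(=O)c1ccc(Cl)cc1` gives -82% in this assay. Compound 3 has the lowest of the three numbers, though the gap to compound 1, a number 8 percentage points lower from compound 1 to compound 3 (within the scatter), lies within the scatter; against compound 2 the difference is large, a number 67 percentage points lower from compound 2 to compound 3 (beyond the scatter).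

Compound 4 `Nc1scc(CN2CCN(c3ccccc3F)CC2)c1C(=O)c1ccc(Cl)cc1` is not yet measured. It differs from compound 3 only in where the fluorine sits on the phenyl ring: 2-fluorophenyl in place of 3-fluorophenyl on an amine nitrogen in a ring

The large steps seen so far, a number 59 percentage points higher from compound 1 to compound 2 (beyond the scatter) and a number 67 percentage points lower from compound 2 to compound 3 (beyond the scatter), both concern replacing a phenyl with a pyridin-4-yl, not a change between two fluorophenyls. Within the data shown here, the only step between two phenyl groups, a number 8 percentage points lower from compound 1 to compound 3 (within the scatter), stays within the scatter. For compound 4 a step of about a number 6 percentage points higher from compound 3 to compound 4 (within the scatter) is therefore expected, that is, none beyond the scatter, and compound 4 is estimated at -76% in this assay, most likely between -95% and -52%.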

Compound 4, a percentage reported as activity, at one concentration (the size of the read-out at that concentration, not a potency): -15%
Compound 4: the middle estimate sits 61 percentage points below what was measured; the measured number lies above the stated range.
By their numbers in this assay, from the lowest: compounds 3 and 1 (each within the scatter of the next); then compounds 2 and 4 (each within the scatter of the next).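

With the same atoms joined differently, moving one fluorine on the phenyl ring gives a number 67 percentage points higher from compound 3 to compound 4 (beyond the scatter) in this assay, so a change between two phenyl groups at this position is not always a small one, as the step from compound 1 to compound 3 alone had suggested. The 2-fluorophenyl group also gives a number 59 percentage points higher from compound 1 to compound 4 (beyond the scatter) and no change at the digits printed from compound 2 to compound 4 (within the scatter), which means that here a phenyl group can read the same as the pyridin-4-yl group. Nothing available explains why the place of the fluorine matters so much.

As far as these compounds go, it remains open whether this loss belongs to fluorine itself or to any group at that place on the ring. A 2-chlorophenyl or 2-methylphenyl group, set against plain phenyl, would separate the two.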